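The source may report more compounds than this note shows. Statements on the series, on what has been measured and on what is new or still open speak of the compounds shown alone.

Measured in a functional assay on SW-620 cells (Homo sapiens) for cytotoxicity, read by MTT assay, with a stated time of 3 days; a higher number here means that more compound is needed for the effect, a lower number that less compound is needed:
- compound 1 `O=C1/C(=C/c2ccccc2[N+](=O)[O-])c2ccccc2N1c1c(Cl)cccc1Cl`: 90 ug/mL
- compound 2 `O=C1/C(=C/c2ccc(F)cc2)c2ccccc2N1c1c(Cl)cccc1Cl`: 5 ug/mL

Of these two compounds, compound 2 holds the lower number, at 5 ug/mL, while compound 1 reads 90 ug/mL. Compound 3 `CN(C)c1ccc(/C=C2/C(=O)N(c3c(Cl)cccc3Cl)c3ccccc32)cc1` has not yet been measured in this assay. It carries dimethylamino in place of fluoro on an aromatic carbon, para to a large group: dimethylamino in place of fluoro on an aromatic carbon. The same difference can be read as 4-fluorophenyl to 4-(dimethylamino)phenyl.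

Among the compounds with values here, only one measured step bears on this change, and only indirectly: an 18-fold lower number from compound 1 to compound 2 (1.26 log units; beyond the scatter), a large step beyond the scatter, with 4-fluorophenyl in place of 2-nitrophenyl. Within the data shown here, it shows that the number can move strongly when this aryl group changes, but no measured compound carries dimethylamino, so the direction stays uncertain. Among the measured compounds shown here, since compound 2 is the lower of only two values, at 5 ug/mL, a moderate rise is expected rather than a further fall. The estimated change is a 2.0-fold higher number from compound 2 to compound 3 (0.30 log units; within the scatter). For compound 3 the expected value is 10 ug/mL, with an estimated range from 2.5 ug/mL to 40 ug/mL.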

Compound 3, concentration for half-maximal effect: > 100 ug/mL
Compound 3 gave a limit, no number; the forecaster's own chance of this, stated with the estimate: 10%; middle value at least 10-fold (1.00 log units) from the limit.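

In this assay, a single exchange on one aromatic carbon, para to a large group, proves enough to move the read-out strongly: dimethylamino in place of fluoro gives an at least 20-fold higher number from compound 2 to compound 3 (1.30 log units; beyond the scatter). The earlier step had replaced 2-nitrophenyl with 4-fluorophenyl, so it could not show that this one position alone carries so much weight. Compound 3 stands at a limit of the assay and not at a number, so the step gives only a floor and its true size stays unknown: the limit of > 100 ug/mL in this assay, at which 1 of the 3 values shown sits.

The comparison with the 2-nitrophenyl compound gives only an at least 1.1-fold higher number from compound 1 to compound 3 (0.04 log units; that floor lies within the scatter), a floor within the scatter, so it does not separate the two compounds. The compounds shown leave open whether a smaller amine, such as a plain amino group, or a methoxy group on this carbon would read closer to compound 2 or to compound 3. They also leave open whether a hydroxyl group or a carboxylic acid there would keep the low number of compound 2, and so whether fluoro itself matters or dimethylamino alone is what raises the number.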